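A Chloro-to-Bromo Exchange Between Two Unreadable Limits

The source may report more compounds than this note shows. Statements on the series, on what has been measured and on what is new or still open speak of the compounds shown alone.

Measured compounds and their values:
compound 1 `CC1(C)CC(NC(=O)Nc2cccc(Cl)c2)c2cc(Cl)ccc2O1`: > 30000 nM
compound 2 `CC1(C)CC(NC(=O)Nc2cccc(Cl)c2)c2cc(Br)ccc2O1`: > 30000 nM
compound 3 `CC1(C)CC(NC(=O)Nc2ccc(Cl)cc2)c2cc(Cl)ccc2O1`: > 300000 nM

Of the compounds shown here, three have been tested in a functional assay (aorta) with Rattus norvegicus as the target; on this read-out lower numbers stand for an effect already at smaller amounts and higher numbers for an effect only at larger amounts of compound. For compound 1 the assay reports only a limit, > 30000 nM. For compound 2 it likewise reports only a limit, > 30000 nM. For compound 3 the result is again a limit, > 300000 nM, and the two further values are limits as well.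

The change from compound 1 to compound 2 is bromo in place of chloro on an aromatic carbon. Its step in this assay, a step that the two limits leave unreadable from compound 1 to compound 2, cannot be read, since both ends sit at the limit of > 30000 nM in this assay, at which 2 of the 3 values shown sit. The cores of compound 1 and compound 3 differ by 4-chlorophenyl in place of 3-chlorophenyl on an amide-type nitrogen, and that step, a step that the two limits leave unreadable from compound 1 to compound 3, is equally unreadable between the limit of > 30000 nM in this assay, at which 2 of the 3 values shown sit, and (the limit of > 300000 nM in this assay, at which 1 of the 3 values shown sits).

Compound 4 `CC1(C)CC(NC(=O)Nc2ccc(Cl)cc2)c2cc(Br)ccc2O1` has not yet been tested. It differs from compound 3 by bromo in place of chloro on an aromatic carbon, the same change as between compound 1 and compound 2, at the same place. Since compound 1 and compound 2 both end at the limit of > 30000 nM in this assay, at which 2 of the 3 values shown sit, the step expected from compound 3 to compound 4 is small, a number no higher from compound 3 to compound 4 (the limit leaves the size open). Compound 4 is therefore expected near 300000 nM, most likely again as a limit.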

Compound 4, half-maximal effective concentration: > 300000 nM
Compound 4: a limit, no number; the forecaster's own chance of this, stated with the estimate: 85%; the middle value sits exactly at the limit.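

In this assay compound 4 gives > 300000 nM, which is a limit and not a number. Neither its step from compound 3 nor its step from compound 2 can be read. The compounds shown leave open whether bromo in place of chloro, or 4-chlorophenyl in place of 3-chlorophenyl, shifts the value in this assay at all.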